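Swapping one triazole for another on the sulfonyl group

The compounds below may be only part of what the source reports. "The series", "measured", "known", "first", "only" and "open" are said of these compounds alone.

Compound 3 `Cn1cnnc1S(=O)(=O)N1CCC(CNC(=O)c2ccc(Cl)cc2Cl)(CC2CC2)CC1` is measured in an assay on JAR cells for inhibition of sodium- and chloride-dependent glycine transporter 1 (Homo sapiens), read by scintillation counting, with a stated time of 3 h (on this read-out higher numbers stand for weaker inhibition and lower numbers for stronger inhibition), where compound 3 gives 124 nM. Among the three measured compounds this places compound 3 second highest: compound 1 `Cn1nncc1S(=O)(=O)N1CC(CNC(=O)c2ccc(Cl)cc2Cl)(CC2CC2)C1` gives 185 nM, within the scatter, while compound 2 `Cn1cc(S(=O)(=O)N2CCC(CNC(=O)c3ccc(Cl)cc3Cl)(CC3CC3)CC2)cn1` gives 10.4 nM. Within the data shown here, the single relevant step is a 12-fold higher number from compound 2 to compound 3 (1.08 log units; beyond the scatter). Compound 4 `CCn1cc(S(=O)(=O)N2CCC(CNC(=O)c3ccc(Cl)cc3Cl)(CC3CC3)CC2)nn1` differs from compound 3 by 1-ethyl-1H-1,2,3-triazol-4-yl in place of 4-methyl-4H-1,2,4-triazol-3-yl on a sulfonyl sulfur. The group entering compound 4 is again attached through a ring carbon and carries an alkyl on a ring nitrogen, as does the group in compound 2, so part of that loss is expected to be regained. Compound 4 is therefore estimated at 35 nM, with a range of 10 nM to 120 nM, an expected step of a 3.5-fold lower number from compound 3 to compound 4 (0.55 log units; beyond the scatter).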

Compound 4, half-maximal inhibitory concentration: 28.2 nM
The estimate for compound 4 lay 1.2-fold (0.09 log units) above the measured number, and the stated range covers the measured number.
By their numbers in this assay, from the lowest: compound 2; then compound 4; then compounds 3 and 1 (each within the scatter of the next).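

Two rings of the same kind, each a five-membered aromatic ring with three hetero atoms, are not interchangeable on the sulfonyl sulfur: this assay shows a 4.4-fold lower number from compound 3 to compound 4 (0.64 log units; beyond the scatter) when 1-ethyl-1H-1,2,3-triazol-4-yl enters. This triazole still does not match 1-methyl-1H-pyrazol-4-yl, as a 2.7-fold higher number from compound 2 to compound 4 (0.43 log units; beyond the scatter) shows. No supporting measurement accounts for either step. On these data alone, it remains open whether the ring's nitrogen arrangement, its point of attachment or the ethyl group drives the change, since these vary together. A 1-methyl-1H-1,2,3-triazol-4-yl group or a longer propyl chain on the same ring would help separate them.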